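The source may hold more compounds than are shown below. What is called first, only, known or untested is meant among the compounds shown, and "the series" means these compounds.

Compound 1 `COc1cc(Cc2nc3c(N)ncnc3n2CC2CC2)cc(OC)c1OC` and compound 2 `CCCCn1c(Cc2cc(OC)c(OC)c(OC)c2Br)nc2c(N)ncnc21` share the same core and were both tested in a functional assay on MCF7 cells (Homo sapiens) for antiproliferative activity; on this read-out lower numbers stand for stronger inhibition and higher numbers for weaker inhibition. Among the measured compounds shown here, compound 1 gives 75900 nM in this assay, which is the highest of the two numbers known so far; compound 2 gives 25100 nM in this assay, a lower number whose distance from compound 1 lies beyond the usual scatter. These two compounds differ in more than one place, so nothing can be read from them about any single change. Compound 3 `COc1cc(Cc2nc3c(N)ncnc3n2CC(OC)OC)cc(OC)c1OC` has not yet been measured in this assay. It differs from compound 1 in one place: dimethoxymethyl in place of cyclopropyl on a saturated chain carbon bound to an aromatic nitrogen. For the measured compounds named here, no pair of measured compounds separated by a single change is available, so there is no step to lean on, and the change from cyclopropyl to dimethoxymethyl on a saturated chain carbon bound to an aromatic nitrogen has no precedent here. The expected step is therefore a 1.3-fold lower number from compound 1 to compound 3 (0.10 log units; within the scatter), small and not clearly beyond the scatter in either direction. Compound 3 is estimated at 60000 nM in this assay, within a range from 20000 nM to 200000 nM.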

Compound 3, half-maximal inhibitory concentration: 72400 nM
For compound 3 the middle estimate is 1.2-fold (0.08 log units) below the measured one, within the range that was stated.
By their numbers in this assay, from the lowest: compound 2; then compounds 3 and 1 (each within the scatter of the next).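

In this assay, putting dimethoxymethyl in place of cyclopropyl on a saturated chain carbon bound to an aromatic nitrogen gives a 1.0-fold lower number from compound 1 to compound 3 (0.02 log units; within the scatter), so this swap leaves no difference that can be told from the usual scatter. Among the compounds shown here, this is the first single-change comparison available, and it shows that two quite different groups can sit at this place with the same result within the scatter: a three-membered ring of carbon only, with no hydrogen-bond acceptors, and an open group with more heavy atoms, including oxygen atoms that count as hydrogen-bond acceptors. Nothing measured here bears on why the two compounds read alike.

One pair cannot show whether the read-out at this place ignores the group in general or whether these two groups simply happen to match, and compound 2 cannot settle this, as it differs from both in more than one place. A charged group such as an amine or a carboxylic acid, or a longer chain on the same carbon, would test whether any group at this place can move the number beyond the scatter.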